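The source may hold more compounds than are shown below. What is called first, only, known or untested is meant among the compounds shown, and "the series" means these compounds.

Two compounds carry numbers here. Compound 1 `O=C(O)c1cccc(Cc2c(-c3ccccc3)nn3ccccc23)n1` has a phenyl group on the shared core, and in a functional assay on cells for antagonist activity at prostaglandin E2 receptor EP1 subtype (Rattus norvegicus), read by fluorescence and calcium flux, with a stated time of 60 s (on this read-out higher numbers stand for weaker inhibition and lower numbers for stronger inhibition), compound 1 gives 2300 nM. Compound 2 `COc1ccc(-c2nn3cc(Cl)ccc3c2Cc2cccc(C(=O)O)n2)cc1` carries a 4-methoxyphenyl group at the same spot and a chlorine on the fused ring system, and in this assay compound 2 gives 5400 nM. Of the two numbers that of compound 2 is the higher, which on this read-out means the weaker inhibition, and the gap to compound 1 lies beyond the usual scatter of repeated measurements.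

Compound 3 `CC(C)(C)c1nn2cc(Cl)ccc2c1Cc1cccc(C(=O)O)n1` has not been measured. It differs from compound 2 in one place: tert-butyl in place of 4-methoxyphenyl on an aromatic carbon. Going by the values given here, nothing among the measured pairs shows a change of this kind, so there is no step to lean on. Both measured compounds carry an aromatic ring at this position, and removing it for a small chain is a departure from both. My expectation is that compound 3 inhibits somewhat less strongly, a step of a 1.7-fold higher number from compound 2 to compound 3 (0.22 log units; within the scatter) that may reach beyond the scatter but could also fall within it. For compound 3 in this assay I estimate 9000 nM, with a range from 3000 nM to 30000 nM.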

Compound 3, half-maximal inhibitory concentration: 48 nM
Beside the measured number, compound 3's estimate is 190-fold (2.27 log units) above it, and the stated range ends above it.
By their numbers in this assay, from the lowest: compound 3; then compound 1; then compound 2.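

In this assay this position on the five-membered aromatic ring proves highly sensitive: tert-butyl in place of 4-methoxyphenyl brings a 110-fold lower number from compound 2 to compound 3 (2.05 log units; beyond the scatter) and so a much stronger inhibition, not the small shift that the earlier numbers left room for. Both earlier compounds carried an aromatic ring at this spot, so they could not show that such a ring is not needed for inhibition here, or that a group with no ring can do far better on this core. What lies behind a change of this size stays unexplained, as nothing measured here speaks to its cause.

The compounds shown leave open whether the gain comes from tert-butyl itself or simply from the loss of the aromatic ring, and a cyclohexyl or an isopropyl group at this position would help to separate the two. Going by these compounds alone, the part played by the chlorine also remains open, since no pair here changes it alone, and a bromine in its place on compound 3 would be one way to probe that site.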